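A Small Methyl Change Tested in Two Related Compounds

The source may report more compounds than this note shows. Statements on the series, on what has been measured and on what is new or still open speak of the compounds shown alone.

Compound 1, `Cc1ccc(C(=O)CCc2nnc(-c3ccccc3)o2)cc1`: 33.3%
Compound 2, `Cc1ccc(C(=O)CCc2nnc(-c3ccccc3)o2)c(C)c1`: 36%
Compound 3, `O=C(CCc1nnc(COc2ccc3ccccc3c2)o1)c1ccccc1`: 29.8%

Of the compounds shown here, three have been tested in a functional assay on the whole organism (strain Wistar) for inhibition, with Rattus norvegicus as the target, with stated times of 30 min and 2 h, at a dose of 20 mg/kg by the oral route; a lower number here means less inhibition, a higher number more inhibition at the dose given (going by the name of the read-out). Compound 1 gives 33.3%, and compound 2 gives 36%. Compound 2 carries one change relative to compound 1, (methyl in place of hydrogen on an aromatic carbon), and that change produced a number 2.7 percentage points higher from compound 1 to compound 2 (within the scatter), so the two numbers cannot be told apart. Compound 3 belongs to a different core, and how its core differs from that of compound 1 is not broken down here. In this assay compound 3 gives 29.8%, which lies within the scatter of both compound 1 and compound 2.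

Compound 4, `Cc1ccc(C(=O)CCc2nnc(COc3ccc4ccccc4c3)o2)cc1`, has not yet been measured. It differs from compound 3 by methyl in place of hydrogen on an aromatic carbon. Among the compounds with values here, this is the same kind of change as the one from compound 1 to compound 2, but it sits at a different place: in compound 2 the new methyl is ortho to a large group and meta to a methyl group, whereas in compound 4 it is para to a large group. Within the data shown here, the only guide available is the earlier pair, where the methyl made a step that stayed within the scatter. On that basis the step from compound 3 to compound 4 is expected to be small, a number 2.7 percentage points higher from compound 3 to compound 4 (within the scatter), because the earlier methyl gave a number 2.7 percentage points higher from compound 1 to compound 2 (within the scatter). In this assay compound 4 is therefore estimated at 32.5%, with a likely range from 22% to 43%.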

Compound 4, a percentage reported as inhibition, in the whole organism at one dose (the size of the read-out at that dose, not a potency): 24.7%
The estimate for compound 4 lay 7.8 percentage points above the measured number; the measured number falls inside the stated range.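

In this assay, the change from phenyl to 4-methylphenyl, a methyl in place of hydrogen on an aromatic carbon, gave a number 5.1 percentage points lower from compound 3 to compound 4 (within the scatter), so compound 3 and compound 4 cannot be told apart. The result on this second core therefore agrees with the earlier one, and the two steps themselves do not differ: the same change on two cores in this assay, a number 2.7 percentage points higher (within the scatter) from compound 1 to compound 2 and a number 5.1 percentage points lower (within the scatter) from compound 3 to compound 4, 7.8 percentage points apart, within the scatter of two such steps

What this shows is modest: on both cores, the methyl produced no step larger than the ordinary spread of repeated measurements, whichever sign the printed numbers carry. Within the data shown here, it does not show that the methyl truly raises or truly lowers inhibition on either core, and with only two pairs, with the methyl at different places on the ring, it gives no general rule for carrying this change across the series.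

The compounds shown have only hydrogen or methyl on this ring, so it remains open whether a different group there, such as an amine, a carboxylic acid or a longer chain, would give a step beyond the scatter. From the compounds shown here alone, it also remains open whether a change elsewhere in these molecules, such as to the chain leading to the carbonyl, would separate any of them in this test.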